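The source may hold more compounds than are shown below. What is called first, only, known or untested is meant among the compounds shown, and "the series" means these compounds.

Compound 1 `Nc1nc(O)c2c(n1)n(C1OC(CO)[C@@H](O)[C@H]1O)c(=O)n2Cc1ccc(Cl)c(Cl)c1` and compound 2 `Nc1nc(O)c2c(n1)n(C1OC(CO)[C@@H](O)[C@H]1O)c(=O)n2Cc1ccc(OCc2ccccc2)cc1` share one core and differ in the group carried on a six-membered aromatic ring of carbon only. In a functional assay on the whole organism (B cells) with Mus musculus as the target (a higher number here means a larger maximal response, a lower number a smaller maximal response), compound 1 gives 55%, whereas compound 2 gives 5%, the lowest of the two numbers, with compound 1 standing higher by a gap beyond the scatter. Compound 3 `Nc1nc(O)c2c(n1)n(C1OC(CO)[C@@H](O)[C@H]1O)c(=O)n2Cc1ccc([N+](=O)[O-])cc1` is still to be measured and carries nitro in place of benzyloxy on an aromatic carbon. Among the measured compounds shown here, with only two measured compounds the size of this step is uncertain, but an upward step of moderate size is expected, estimated as a number 25 percentage points higher from compound 2 to compound 3 (beyond the scatter). Compound 3 is expected to give 30%, within 5% to 60%.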

Compound 3, largest response reached (reported as maximal response), in percent of the reference or control that the assay uses: 147%
Beside the measured number, compound 3's estimate is 117 percentage points below it; measured number above the stated range.
By their numbers in this assay, from the lowest: compound 2; then compound 1; then compound 3.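

In this assay, nitro in place of benzyloxy gives a number 142 percentage points higher from compound 2 to compound 3 (beyond the scatter), and 4-nitrophenyl in place of 3,4-dichlorophenyl gives a number 92 percentage points higher from compound 1 to compound 3 (beyond the scatter). The group on this aromatic ring can therefore carry the response far past that of both earlier compounds, whose top value, for compound 1, was 55%. No measurement available here explains the size of these steps. Going by these compounds, it remains open whether an amine, a nitrile or a carboxylic acid at the same place would match nitro. On these data alone, whether a methoxy group would fall closer to benzyloxy also remains open.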